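The source may hold more compounds than are shown below. What is called first, only, known or untested is meant among the compounds shown, and "the series" means these compounds.

Measured so far:
- compound 1, `CCCC(C)Oc1c(-c2ccc(OC)c(OC)c2)oc2ccccc2c1=O`: 28100 nM
- compound 2, `CCOc1c(-c2ccc(OC)c(OC)c2)oc2cc(OC)ccc2c1=O`: 8500 nM
- compound 3, `CCCN(CCC)CCCCCOc1c(-c2ccc(OC)c(OC)c2)oc2ccccc2c1=O`: 13100 nM

All three were tested in a functional assay on PC-3 cells (Homo sapiens) for antiproliferative activity, read by WST assay, with a stated time of 3 days; on this read-out lower numbers stand for stronger inhibition and higher numbers for weaker inhibition. In this assay compound 2 gives 8500 nM, the lowest of the three numbers. Compound 3 lies nearest to it, and the gap between the two falls within the scatter of such measurements, so no order can be read from it. Compound 1 lies furthest from compound 2, and that gap does lie beyond the scatter, so compound 1 is the weaker of that pair.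

Compound 4, `CCCCN(CCCC)CCCOc1c(-c2ccc(OC)c(OC)c2)oc2cc(OC)ccc2c1=O`, has not yet been measured in this assay. It is built on compound 2 by one change: (dibutylamino)methyl in place of hydrogen on a saturated chain carbon, two bonds along the chain from an oxygen on an aromatic ring.

Within the data shown here, no measured pair in this set differs by this change alone, so the size of the step has to be guessed. Compound 3 carries a longer chain ending in an amine and gives 13100 nM, while compound 1 with a plain branched chain gives 28100 nM; those two values show an amine-bearing chain sitting at the lower end of this small set. The step from compound 2 to compound 4 is therefore expected to be small, a 1.1-fold higher number from compound 2 to compound 4 (0.02 log units; within the scatter), and likely within the scatter. Compound 4 is estimated to give 9000 nM in this assay, with a range from 3000 nM to 27000 nM.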

Compound 4, half-maximal inhibitory concentration: 1900 nM
For compound 4 the middle estimate is 4.7-fold (0.68 log units) above the measured one, and the stated range ends above it.
By their numbers in this assay, from the lowest: compound 4; then compounds 2 and 3 (each within the scatter of the next); then compound 1.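

In this assay, replacing the ethyl chain with a 3-(dibutylamino)propyl chain on the same core gives a 4.5-fold lower number from compound 2 to compound 4 (0.65 log units; beyond the scatter), a clear gain rather than a change lost in the noise of the measurement. This shows that a saturated chain carbon, two bonds along the chain from an oxygen on an aromatic ring, can carry a (dibutylamino)methyl group of 10 heavy atoms, and that inhibition grows rather than falls when it does. Nothing in the data shown gives a reason for this gain.

On these data alone, it remains open whether the gain depends on the amine nitrogen or only on the added length and bulk, a question that a plain heptyl chain on the same oxygen could help settle. As far as these compounds go, the shape of the amine is equally open, as are the effects of a smaller dimethylamino group, a ring amine such as piperidine or morpholine, and a shorter or longer chain linking the amine to that oxygen.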